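Meta-methoxy anilide of a nitro-sulfonyl core

The compounds below may be only part of what the source reports. "The series", "measured", "known", "first", "only" and "open" are said of these compounds alone.

The account concerns a small set of anilides built on one shared core. Compound 1 `O=[N+]([O-])c1ccc2c(c1)S(=O)(=O)N=C2Nc1ccccc1` is the parent; in an assay on isolated protein for inhibition of Polyunsaturated fatty acid 5-lipoxygenase (Homo sapiens), read by fluorescence and spectrophotometry, with a stated time of 10 min (a higher number here means a weaker inhibitor, a lower number a stronger inhibitor), compound 1 gives 8600 nM. Among the numbers shown it holds the lowest one, with compound 2 `COc1ccc(NC2=NS(=O)(=O)c3cc([N+](=O)[O-])ccc32)cc1` nearest: in this assay compound 2 gives 12300 nM. Compound 3 `Cc1ccccc1NC1=NS(=O)(=O)c2cc([N+](=O)[O-])ccc21` reaches only a limit of the assay; in this assay compound 3 gives > 50000 nM, a limit and not a number (the limit of > 50000 nM in this assay, at which 1 of the 3 values shown sits).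

Two measured steps start from compound 1. The first, a 1.4-fold higher number from compound 1 to compound 2 (0.16 log units; within the scatter), stays within the scatter. The second, an at least 5.8-fold higher number from compound 1 to compound 3 (0.76 log units; beyond the scatter), is at least modest and goes beyond it.

Compound 4 `COc1cccc(NC2=NS(=O)(=O)c3cc([N+](=O)[O-])ccc32)c1` is not yet measured. It differs from compound 1 by methoxy in place of hydrogen on an aromatic carbon. For the measured compounds named here, of the two measured steps, the one to compound 2 carries the same entering group, since a 1.4-fold higher number from compound 1 to compound 2 (0.16 log units; within the scatter) also concerns a methoxy, and it produced no change beyond the scatter; the one to compound 3 concerns a different group and is set aside. Compound 4 is therefore expected to sit close to compound 1, with a 1.4-fold higher number from compound 1 to compound 4 (0.14 log units; within the scatter) as the expected step. For compound 4 in this assay the estimate is 12000 nM, expected to fall between 5000 nM and 40000 nM.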

Compound 4, half-maximal inhibitory concentration: 240 nM
Compound 4: the middle estimate sits 50-fold (1.70 log units) above what was measured, outside the stated range (below it).
By their numbers in this assay, from the lowest: compound 4; then compounds 1 and 2 (each within the scatter of the next). At a limit, above all of these: compound 3.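

Set on an aromatic carbon meta to a large group, methoxy in place of hydrogen gives a 36-fold lower number from compound 1 to compound 4 (1.55 log units; beyond the scatter) in this assay, which is a large step. The same entering group at another place on that ring gave a 1.4-fold higher number from compound 1 to compound 2 (0.16 log units; within the scatter), so among these compounds the effect of a methoxy depends on where it stands and not merely on its presence. In this assay, compound 2 gives 12300 nM and compound 4 gives 240 nM, although the two carry the same group on the same ring.

The values shown do not tell why this place gives such a gain, nor whether a hydroxyl, an ethoxy or an amine at the same place would keep it. Compound 3, the only methyl shown, stands at a limit and not a number, and it says nothing about how a methyl would behave at the place the methoxy holds in compound 4: the limit of > 50000 nM in this assay, at which 1 of the 4 values shown sits.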